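Acrylamide triazines against Raji cells: a tail swap

The source may hold more compounds than are shown below. What is called first, only, known or untested is meant among the compounds shown, and "the series" means these compounds.

Compound 1, `C=CC(=O)Nc1cccc(Nc2ncnc(Nc3ccc(C(=O)Nc4ccc(C)cn4)cc3)n2)c1`, gives 125000 nM in a functional assay on Raji cells (Homo sapiens) for antiproliferative activity, read by CCK-8 assay, with a stated time of 24 h; a higher number here means a weaker inhibitor, a lower number a stronger inhibitor.
Compound 2, `C=CC(=O)Nc1cccc(Nc2ncnc(Nc3ccc(-c4ccc(Cl)nc4)cc3)n2)c1`, is recorded as "not determined" (no result reported) in this assay, so it has no number there.

Three compounds share one core: an acrylamide-bearing aniline attached to a triazine, which in turn carries a second aniline. Only the group at the far end of that second aniline changes. Compound 1 is a very weak inhibitor in this assay. Compound 2 stands nowhere on the numbers, since no result was reported for it, so the position of its chloropyridinyl tail cannot be placed against compound 1.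

Compound 3, `C=CC(=O)Nc1cccc(Nc2ncnc(Nc3ccc(OCCOC)cc3)n2)c1`, is the next compound. It differs from compound 2 as follows: 2-methoxyethoxy in place of 6-chloropyridin-3-yl on an aromatic carbon. The change is 2-methoxyethoxy in place of 6-chloropyridin-3-yl, made at the same position. Among the measured compounds shown here, with no number for compound 2 and only one very weak value in the set, there is no measured step to lean on, so no direction beyond the scatter is expected in this assay. Compound 3 is expected to give about 100000 nM, in the range 20000 nM to 400000 nM.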

Compound 3, half-maximal inhibitory concentration: 105000 nM
For compound 3 the middle estimate is 1.1-fold (0.02 log units) below the measured one; the measured number falls inside the stated range.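

In this assay the swap of (5-methylpyridin-2-yl)carbamoyl for 2-methoxyethoxy gives a 1.2-fold lower number from compound 1 to compound 3 (0.08 log units; within the scatter) and so makes no real difference to the read-out. Among the compounds shown here, this is the first comparison in the set with a number at both ends, and it shows that two quite different tails, one containing a pyridine ring and one an open chain with no ring, give the same very weak result at this position on the second aniline. The step from compound 2 to compound 3 cannot be read, since compound 2 has no number, and the 6-chloropyridin-3-yl tail remains unplaced. No measurement available here accounts for why the two tails read alike.

For the compounds shown here, with only two numbers, both very weak, it remains open whether any group at this position can move the result at all. A basic amine such as a piperazine, a carboxylic acid or a longer ether chain in the same place would test that, and those compounds would show whether this end of the molecule has any bearing on activity against these cells.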